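Chloro to methyl exchange: working notes toward compound 4

The compounds below may be only part of what the source reports. "The series", "measured", "known", "first", "only" and "open" are said of these compounds alone.

Values in an ADME assay on MRC5 cells (Homo sapiens) for cytotoxicity, read by MTT assay, with a stated time of 72 h; on this read-out lower numbers stand for stronger inhibition and higher numbers for weaker inhibition:
Compound 1 `O=C(Nc1nnc(-c2cccc(O)c2O)s1)c1ccc(Cl)cc1`: 18700 nM
Compound 2 `Cc1ccc(C(=O)Nc2nnc(-c3ccc(O)c(O)c3)s2)cc1`: 27100 nM
Compound 3 `O=C(Nc1nnc(-c2ccc(O)c(O)c2)s1)c1ccc(Cl)cc1`: 30600 nM
Compound 4 `Cc1ccc(C(=O)Nc2nnc(-c3cccc(O)c3O)s2)cc1`: not yet measured

The three measured numbers lie within the scatter of one another, so compound 1 at 18700 nM is not separated from compound 2 or from compound 3 on these data.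

Compound 4 differs from compound 1 in one place: methyl in place of chloro on an aromatic carbon. In words, this is methyl in place of chloro on an aromatic carbon, para to a large group, so that 4-chlorophenyl becomes 4-methylphenyl.

Within the data shown here, one measured step bears on this exchange: a 1.1-fold higher number from compound 2 to compound 3 (0.05 log units; within the scatter). It is the same exchange run in the opposite direction, and the rest of that pair is not identical to the rest of compound 1. That step lies within the scatter. It is a single pair, so the support is thin, but it gives no reason to expect a real shift. In this assay, no step beyond the scatter is expected, and no direction can be assigned.

The expected step is a 1.0-fold higher number from compound 1 to compound 4 (0.01 log units; within the scatter). For compound 4 the estimate is 19000 nM, with an expected range from 11000 nM to 33000 nM.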

Compound 4, half-maximal inhibitory concentration: 33200 nM
Compound 4: middle estimate off by 1.7-fold (0.24 log units), on the low side; measured number above the stated range.
By their numbers in this assay, from the lowest: compounds 1, 2, 3 and 4 (each within the scatter of the next).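

In this assay, the exchange of 4-chlorophenyl for 4-methylphenyl can now be read on a second core, and there it gives a 1.8-fold higher number from compound 1 to compound 4 (0.25 log units; within the scatter). Where the earlier compounds offered a single pair, two pairs now show the same outcome at this position: on neither core are the chloro and methyl compounds separated by the measurement. The printed steps point in different directions when read from methyl to chloro, but that difference cannot be taken as a real dependence on the core, as the gap between the two steps also stays within the scatter: the same change on two cores in this assay, a 1.1-fold higher number (0.05 log units; within the scatter) from compound 2 to compound 3 and a 1.8-fold lower number (0.25 log units; within the scatter) from compound 4 to compound 1, 2.0-fold (0.30 log units) apart, within the scatter of two such steps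

Only chloro and methyl are shown on this aromatic carbon, so it remains open whether an amine, a carboxylic acid or a longer chain such as n-butyl at the same place would give a step beyond the scatter in this assay. Also open is whether the exchange would stay within the scatter on a third core, since the compounds shown cover only two.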